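Swapping one alkenyl arm for another: a cytotoxicity outlook

The compounds below may be only part of what the source reports. "The series", "measured", "known", "first", "only" and "open" are said of these compounds alone.

Measured compounds:
compound 1 `CC(C)=CCN1C(=O)N(Cc2ccccc2)S(=O)(=O)n2cccc21`: 226000 nM
compound 2 `N#Cc1ccccc1CN1C(=O)N(Cc2cccc(Cl)c2)S(=O)(=O)n2cccc21`: > 293000 nM

Among the compounds with values here, in an ADME assay on MT4 cells (Homo sapiens) for cytotoxicity, read by MTT assay, with a stated time of 5 days (on this read-out lower numbers stand for higher toxicity in this test and higher numbers for lower toxicity in this test), compound 1 gives 226000 nM, the only plain number seen here. For compound 2 the read-out is a limit of the test rather than a number, > 293000 nM. Compound 3 `O=C1N(C/C=C/c2ccccc2)c2cccn2S(=O)(=O)N1Cc1ccccc1` differs from compound 1 by 2-phenylethenyl in place of 2-methylprop-1-en-1-yl on a saturated chain carbon bound to an amide-type nitrogen in a ring. Within the data shown here, no pair of measured compounds shows this kind of change, so there is no measured step to lean on. The expected step is therefore small, a 1.4-fold lower number from compound 1 to compound 3 (0.15 log units; within the scatter), not beyond the usual scatter. Compound 3 is estimated at 160000 nM in this assay, between 60000 nM and 320000 nM.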

Compound 3, half-maximal cytotoxic concentration: > 318000 nM
Compound 3: a limit, no number; the forecaster's own chance of this, stated with the estimate: 30%; middle value at least 1.9-fold (0.29 log units) from the limit.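

Within the data shown here, putting 2-phenylethenyl in place of 2-methylprop-1-en-1-yl on this saturated chain carbon gives the first measured step for this change in this assay: an at least 1.4-fold higher number from compound 1 to compound 3 (0.14 log units; that floor lies within the scatter). For compound 3 the read-out is a limit, not a number: > 318000 nM. An aromatic ring on this arm therefore brings no sign of higher toxicity in this test, although the floor of the step lies within the scatter.

On these data alone, the true size of the step remains open. So does the outcome for an arm ending in an amine or a carboxylic acid at this place.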